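Isopropyl on the Aromatic Ring: Expected Loss of Inhibition

The compounds below may be only part of what the source reports. "The series", "measured", "known", "first", "only" and "open" are said of these compounds alone.

Compound 1, `O=C(O)c1cc(CCCCNS(=O)(=O)c2ccccc2)c2cccccc1-2`, gives 570 nM in a functional assay (thoracic aorta) for inhibition, with Rattus norvegicus as the target; a lower number here means a stronger inhibitor, a higher number a weaker inhibitor.
Compound 2, `O=C(O)c1cc(CCCCCCNS(=O)(=O)c2ccccc2)c2cccccc1-2`, gives 140 nM in this assay.
Compound 3, `CC(C)c1cccc2c(CCCCNS(=O)(=O)c3ccccc3)cc(C(=O)O)c-2c1`, gives 3100 nM in this assay.

All three measured compounds carry a carboxylic acid on a fused aromatic core and a chain ending in a sulfonamide. Compound 1 and compound 2 differ in the length of that chain; the difference between these two cores is not broken down here, and the values simply show that compound 2 gives the lowest number of the three in this assay. Compound 3 arises from compound 1 by one change, (isopropyl in place of hydrogen on an aromatic carbon), and that change produced a 5.4-fold higher number from compound 1 to compound 3 (0.74 log units; beyond the scatter), a weakening of inhibition that lies beyond the usual scatter.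

Compound 4, `CC(C)c1cccc2c(CCCCCCNS(=O)(=O)c3ccccc3)cc(C(=O)O)c-2c1`, has not yet been measured in this assay. For the measured compounds named here, it arises from compound 2 by isopropyl in place of hydrogen on an aromatic carbon, which is the same change as the one from compound 1 to compound 3, at the same kind of place on the same core. Going by the values given here, it is therefore expected that compound 4 will show a 5.4-fold higher number from compound 2 to compound 4 (0.73 log units; beyond the scatter), because a 5.4-fold higher number from compound 1 to compound 3 (0.74 log units; beyond the scatter) is the only comparable step known here. On that basis compound 4 is estimated at 750 nM in this assay, with a likely range from 300 nM to 2000 nM. Whether the step is reproduced at the longer chain of compound 2 rests on a single precedent, so the range is kept wide.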

Compound 4, half-maximal inhibitory concentration: 920 nM
Estimate against measurement, compound 4: 1.2-fold (0.09 log units) below, and the stated range covers the measured number.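

Replacing hydrogen with isopropyl on an aromatic carbon of the seven-membered ring weakened inhibition in this assay on the core of compound 2 as well, with a 6.6-fold higher number from compound 2 to compound 4 (0.82 log units; beyond the scatter). Set beside the earlier step, the change costs about the same on both cores, so the two steps cannot be told apart: the same change on two cores in this assay, a 5.4-fold higher number (0.74 log units; beyond the scatter) from compound 1 to compound 3 and a 6.6-fold higher number (0.82 log units; beyond the scatter) from compound 2 to compound 4, 1.2-fold (0.08 log units) apart, within the scatter of two such steps. In this small series, then, the size of the loss carried over from one chain length to the other, but two pairs show only that it held in these two cases, not that it would hold on a different core, and they do not explain what causes the loss.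

The compounds shown leave open whether a methyl or a tert-butyl group on the same aromatic carbon would cost as much as isopropyl, since only hydrogen and isopropyl appear there. They also leave open whether the step would stay the same with a longer chain than that of compound 2, or with an amide or a tetrazole in place of the carboxylic acid.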